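Aryl swap on the thiomethyl arm: expectation for compound 3

The compounds below may be only part of what the source reports. "The series", "measured", "known", "first", "only" and "open" are said of these compounds alone.

Compound 2 `Clc1ccc(CSc2nnc(-c3ccncc3)n2-c2ccccc2)cc1` stands lowest of the two numbers in a functional assay on HCT-116 cells (Homo sapiens) for inhibition, read by MTT assay, with a stated time of 48 h (a higher number here means a weaker inhibitor, a lower number a stronger inhibitor), at 10700 nM. Its nearest neighbour, compound 1 `Fc1ccccc1CSc1nnc(-c2ccncc2)n1-c1ccccc1`, gives 12000 nM in this assay, and the pair lies within the scatter, a 1.1-fold lower number from compound 1 to compound 2 (0.05 log units; within the scatter). Compound 3 `O=[N+]([O-])c1ccccc1CSc1nnc(-c2ccncc2)n1-c1ccccc1` carries 2-nitrophenyl in place of 4-chlorophenyl on a saturated chain carbon bound to a sulfur. Within the data shown here, the only measured step bearing on this change is the aryl swap on the same carbon, a 1.1-fold lower number from compound 1 to compound 2 (0.05 log units; within the scatter), which stayed within the scatter; no step beyond the scatter is therefore expected in this assay, the expected step being a 1.0-fold higher number from compound 2 to compound 3 (0.01 log units; within the scatter). Compound 3 is estimated at 11000 nM, within a range from 5000 nM to 25000 nM.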

Compound 3, half-maximal inhibitory concentration: > 50000 nM
Compound 3 was reported as a limit; the forecaster's own chance of this, stated with the estimate: 5%; middle value at least 4.5-fold (0.65 log units) from the limit.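

On the saturated chain carbon bound to a sulfur, the aryl group now matters in this assay: 2-nitrophenyl in place of 4-chlorophenyl gives an at least 4.6-fold higher number from compound 2 to compound 3 (0.66 log units; beyond the scatter), whereas the swap between the two halogen-bearing aryl groups stayed within the scatter, with a 1.1-fold lower number from compound 1 to compound 2 (0.05 log units; within the scatter). Nitro in place of fluoro on an aromatic carbon gives an at least 4.1-fold higher number from compound 1 to compound 3 (0.61 log units; beyond the scatter), so the loss appears against both. Compound 3 stands only as a limit: the limit of > 50000 nM in this assay, at which 1 of the 3 values shown sits.

On these data alone, whether the loss belongs to the nitro group itself or to its place on the ring stays open. An amine or a carboxylic acid in place of the nitro group would show whether other non-halogen groups are tolerated here.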